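From Chlorobenzyl to Cyanobenzyl: Expected Cytotoxicity Shift

A few compounds are considered here, and "the series" means these few. Any claim that something is new, unique, unknown or untested is made for them only; others in the source may bear on it.

Measured in a functional assay on MDA-MB-231 cells (Homo sapiens) for cytotoxicity, read by MTT assay, with a stated time of 48 h; a lower number here means a stronger inhibitor, a higher number a weaker inhibitor:
compound 1, `Cc1ccc(Cn2cc(COc3ccc4c(=O)ccoc4c3)nn2)cc1`, gives > 100000 nM, a limit of the assay
compound 2, `O=c1ccoc2cc(OCc3cn(Cc4ccccc4Cl)nn3)ccc12`, gives 15100 nM

Compound 2 holds the only number shown in this assay. Compound 1 stands at the limit of > 100000 nM in this assay, at which 1 of the 2 values shown sits. The step from compound 1 to compound 2 was an at least 6.6-fold lower number from compound 1 to compound 2 (0.82 log units; beyond the scatter). Compound 3, `N#Cc1cccc(Cn2cc(COc3ccc4c(=O)ccoc4c3)nn2)c1`, differs from compound 2 by 3-cyanophenyl in place of 2-chlorophenyl on a saturated chain carbon bound to an aromatic nitrogen. Within the data shown here, only that single step bears on this change, and it concerns a different substituent, so it sets no firm direction. A modest weakening is expected for compound 3 in this assay, a 2.0-fold higher number from compound 2 to compound 3 (0.30 log units; within the scatter). Compound 3 is estimated at 30000 nM, with a range from 10000 nM to 100000 nM.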

Compound 3, half-maximal inhibitory concentration: > 100000 nM
Compound 3: a limit, no number (the forecaster's own chance of this, stated with the estimate: 25%); middle value at least 3.3-fold (0.52 log units) away from the limit.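

In this assay, the change to 3-cyanophenyl on a saturated chain carbon bound to an aromatic nitrogen gives an at least 6.6-fold higher number from compound 2 to compound 3 (0.82 log units; beyond the scatter). This shows that a second, different group at this position also ends at a limit rather than a number, leaving compound 2 alone with a measured value: the limit of > 100000 nM in this assay, at which 2 of the 3 values shown sit. The step between compound 1 and compound 3 cannot be read, as both values are limits.

As far as these compounds go, whether 2-cyanophenyl or 3-chlorophenyl at this position would give a number in this assay remains open.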